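The source may report more compounds than this note shows. Statements on the series, on what has been measured and on what is new or still open speak of the compounds shown alone.

The study centres on compound 1, `CNC(=O)CCCCCCCn1nc(-c2ccc3oc(N)nc3c2)c2c(N)ncnc21`, whose activity is followed in a functional assay on HCT-116 cells (Homo sapiens) for inhibition, read by MTT assay, with a stated time of 72 h; on this read-out lower numbers stand for stronger inhibition and higher numbers for weaker inhibition. Compound 1 gives 3150 nM, the lowest of the three numbers recorded. Compound 3, `Nc1ncnc2c1c(-c1cnc3[nH]ccc3c1)nn2CCCCCCC(=O)NO`, gives 9860 nM, and compound 2, `Nc1nc2cc(-c3nn(CCCCCCCCCC(=O)NO)c4ncnc(N)c34)ccc2o1`, gives 23100 nM, the highest of the three.

The compound to be considered next is compound 4, `Nc1nc2cc(-c3nn(CC(=O)NO)c4ncnc(N)c34)ccc2o1`. Its structure differs from that of compound 1 in one place: hydroxycarbamoyl in place of 6-(methylcarbamoyl)hexyl on a saturated chain carbon bound to an aromatic nitrogen. Among the compounds with values here, the only measured step that bears on this change is the one from compound 1 to compound 2, in which a hydroxycarbamoyl group also took the place of the methylcarbamoyl group, though at a different distance along the chain; that step gave a 7.3-fold higher number from compound 1 to compound 2 (0.87 log units; beyond the scatter). Within the data shown here, nothing among the measured compounds shows a hydroxycarbamoyl group sitting on the chain carbon bound to the aromatic nitrogen, so the effect of the much shorter chain itself has no direct precedent here.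

On the strength of that one step, compound 4 is expected to weaken by a 6.3-fold higher number from compound 1 to compound 4 (0.80 log units; beyond the scatter) in this assay. Compound 4 is therefore estimated at 20000 nM, with a likely range from 6000 nM to 70000 nM.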

Compound 4, half-maximal inhibitory concentration: 11400 nM
Beside the measured number, compound 4's estimate is 1.8-fold (0.24 log units) above it; low and high end bracket the measured number.
By their numbers in this assay, from the lowest: compound 1; then compounds 3 and 4 (each within the scatter of the next); then compound 2.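

In this assay, putting hydroxycarbamoyl in place of 6-(methylcarbamoyl)hexyl on a saturated chain carbon bound to an aromatic nitrogen gives a 3.6-fold higher number from compound 1 to compound 4 (0.56 log units; beyond the scatter), so this much smaller group does not match the number of compound 1. The earlier compounds shown here showed the hydroxycarbamoyl group only at the end of a long chain, as in compound 2 at 23100 nM; compound 4, which has lost that chain, still gives a measurable number at 11400 nM, so inhibition in this read-out does not depend on a long chain at this position. Nothing shown explains why the number shifts as it does at this position, and no measurement beyond the cell read-out bears on it.

The change in compound 4 removes the chain and alters the end group at once, so the compounds shown cannot say how much of the step belongs to each. Going by these compounds, a methylcarbamoyl group on this same carbon, or a carboxylic acid or an amine in place of the hydroxycarbamoyl group, would be needed to separate the two, and how chains of intermediate length behave on the core of compound 1 also remains open.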